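Swapping the Ring on the Side Chain

This account rests on a few compounds, and the source may have more. Where it says the series, first, only, none or still open, it means among the compounds named here.

Compound 2, with the structure `CNc1nccc(N2CC[C@H](NC(=O)Nc3ccc(CN4CCN(C)CC4)c(C(F)(F)F)c3)C2)n1`, was measured in an ADME assay on a cell-free system (plasma, Mus musculus) for protein binding, and gave 85.8%. Among the three compounds measured so far it shows the highest unbound fraction. Compound 3, `CNc1nccc(N2CC[C@H](NC(=O)Nc3cccc(C#N)c3)C2)n1`, gives 91.5% in this assay, which lies within the usual scatter of compound 2. Compound 1, `CNc1nccc(N2CC[C@H](NC(=O)Nc3ccc(OC(F)(F)F)cc3)C2)n1`, gives 98.1% in this assay, a gap from compound 2 that goes beyond the scatter.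

Compound 4, `CNc1nccc(N2CC[C@H](NC(=O)Nc3ccc(CN4CCCC4)c(C(F)(F)F)c3)C2)n1`, has not yet been measured. It differs from compound 2 in one place: pyrrolidin-1-yl in place of 4-methylpiperazin-1-yl on a saturated chain carbon bound to an aromatic carbon. Within the data shown here, no measured pair of compounds carries exactly this change, so nothing here shows its size directly.

The change keeps the shared core and the urea unit of compound 2 and only exchanges the ring at the end of the side chain. The step from compound 2 to compound 4 is therefore expected to be small, a slight shift toward more binding that stays within the scatter, written as a 1.3-fold lower unbound fraction from compound 2 to compound 4 (0.11 log units; within the scatter). Compound 4 is estimated at 89%, with a range from 80% to 95%.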

Compound 4, plasma protein binding: 87.2%
Beside the measured number, compound 4's estimate is 1.2-fold (0.07 log units) (unbound fraction) below it; measured number inside the range.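

Among these compounds, this is the first direct reading of a single change at this position. In this assay, placing pyrrolidin-1-yl where 4-methylpiperazin-1-yl stood, on a saturated chain carbon bound to an aromatic carbon, gives a 1.1-fold lower unbound fraction from compound 2 to compound 4 (0.05 log units; within the scatter), so this assay cannot tell the two rings apart in this pair, even though the entering ring has fewer heavy atoms and one hetero atom instead of two. Nothing available explains why the two rings read alike.

Two rings at one position cannot show how much freedom that position allows. An open-chain amine such as dimethylamino, a morpholine ring, or a carboxylic acid at the end of the same side chain could show whether any replacement there moves the read-out beyond the scatter.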